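This account rests on a few compounds, and the source may have more. Where it says the series, first, only, none or still open, it means among the compounds named here.

Measured compounds:
- compound 1 `CCCCc1nc(=O)c(S(=O)(=O)c2ccc(-c3ccc(F)nc3)cc2)c(O)n1-c1c(OC)cccc1OC`: 516 nm/s in an ADME assay for permeability, using PAMPA, at pH 5.5; on this read-out higher numbers stand for higher permeability and lower numbers for lower permeability
- compound 2 `CCCCc1nc(=O)c(S(=O)(=O)c2ccc(-n3cc(Cl)ccc3=O)cc2)c(O)n1-c1c(OC)cccc1OC`: 83 nm/s in this assay

Within the data shown here, compound 2 stands at the lower of the two numbers, and the only step measured so far, a 6.2-fold lower number from compound 1 to compound 2 (0.79 log units; beyond the scatter), separates it from compound 1. Compound 3 `CCCCc1nc(=O)c(S(=O)(=O)c2ccccc2)c(O)n1-c1c(OC)cccc1OC` differs from compound 2 by a hydrogen atom in place of a group of 8 heavy atoms (5 carbon, 1 nitrogen, 1 oxygen, 1 chlorine; one six-membered aromatic ring with 1 hetero atom), on an aromatic carbon: the whole ring that entered in the step to compound 2 is taken away and nothing but a hydrogen is left at that aromatic carbon, para to a large group. Among the measured compounds shown here, no measured step removes a group at this position, so the only guide is that adding this ring in the step from compound 1 to compound 2 lowered the number beyond the scatter. Taking it away again is expected to raise the number, a step of about a 4.8-fold higher number from compound 2 to compound 3 (0.68 log units; beyond the scatter). Compound 3 is therefore expected to give about 400 nm/s, with a range from 150 nm/s to 1100 nm/s.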

Compound 3, apparent permeability: 141 nm/s
Compound 3: the middle estimate sits 2.8-fold (0.45 log units) above what was measured; the measured number lies below the stated range.
By their numbers in this assay, from the lowest: compounds 2 and 3 (each within the scatter of the next); then compound 1.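

In this assay, taking the whole ring off the aromatic carbon and leaving only a hydrogen gives a step that cannot be told from the usual scatter (a 1.7-fold higher number from compound 2 to compound 3 (0.23 log units; within the scatter)), so this read-out does not separate the ring of compound 2 from hydrogen at this position. Hydrogen in place of 6-fluoropyridin-3-yl gives a clear step (a 3.7-fold lower number from compound 1 to compound 3 (0.56 log units; beyond the scatter)), so of these three compounds it is compound 1 that stands apart, which the single earlier step could not show. Nothing measured here gives a reason for this pattern.

On these data alone, it remains open whether the fluorine or the pyridine ring itself goes with the higher number of compound 1, as a pyridin-3-yl group without fluorine or a plain phenyl ring would test. A small group on this carbon, such as methoxy or an amine, could read with either side.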